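Adding a Small Carbamate to the Ethyl Sulfonyl Chain

A few compounds are considered here, and "the series" means these few. Any claim that something is new, unique, unknown or untested is made for them only; others in the source may bear on it.

Three compounds share one core and differ only in the group on the sulfonyl sulfur. Compound 1 `CC(C)OC(=O)NCCS(=O)(=O)NC(=O)c1ccc(Nc2nc(NC3(c4ccc(Cl)cc4)CC3)nc(OCC(F)(F)F)n2)cc1` carries a 2-((isopropoxycarbonyl)amino)ethyl there, and in an ADME assay on microsomes from liver (Homo sapiens) for metabolic stability, with a stated time of 10 min (on this read-out higher numbers stand for a more stable compound and lower numbers for a less stable compound), compound 1 gives 100%. Compound 2 `CC(C)S(=O)(=O)NC(=O)c1ccc(Nc2nc(NC3(c4ccc(Cl)cc4)CC3)nc(OCC(F)(F)F)n2)cc1` carries an isopropyl, and in this assay compound 2 gives 100%. Compound 3 `CCS(=O)(=O)NC(=O)c1ccc(Nc2nc(NC3(c4ccc(Cl)cc4)CC3)nc(OCC(F)(F)F)n2)cc1` carries an ethyl, and in this assay compound 3 gives 100%. Compound 3 thus stands level with both neighbours: no change at the digits printed from compound 1 to compound 2 (within the scatter), no change at the digits printed from compound 1 to compound 3 (within the scatter) and no change at the digits printed from compound 2 to compound 3 (within the scatter) all lie within the scatter.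

Compound 4 `COC(=O)NCCS(=O)(=O)NC(=O)c1ccc(Nc2nc(NC3(c4ccc(Cl)cc4)CC3)nc(OCC(F)(F)F)n2)cc1` differs from compound 3 by (methoxycarbonyl)amino in place of hydrogen on a saturated chain carbon, two bonds along the chain from a sulfonyl sulfur. The closest measured comparison is no change at the digits printed from compound 1 to compound 3 (within the scatter), which removed (isopropoxycarbonyl)amino from the very same place without moving the read-out, and the other two steps were equally flat. Nothing in these data points to a shift beyond the scatter. Compound 4 is therefore expected to give 100%, within 90% to 100%. The expected step, no change at the digits printed from compound 3 to compound 4 (within the scatter), is estimated to stay within the scatter.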

Compound 4, percent of the compound remaining: 90%
For compound 4 the middle estimate is 10 percentage points above the measured one, and the stated range covers the measured number.
By their numbers in this assay, from the lowest: compounds 4, 1, 2 and 3 (each within the scatter of the next).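

In this assay, adding (methoxycarbonyl)amino on a saturated chain carbon, two bonds along the chain from a sulfonyl sulfur, gives a number 10 percentage points lower from compound 3 to compound 4 (within the scatter) and so shows that this small carbamate is tolerated here, as the isopropyl version was. The end of the carbamate makes no clear difference either: methyl in place of isopropyl on an oxygen next to a carbonyl group gives a number 10 percentage points lower from compound 1 to compound 4 (within the scatter) and 2-((methoxycarbonyl)amino)ethyl in place of isopropyl on a sulfonyl sulfur gives a number 10 percentage points lower from compound 2 to compound 4 (within the scatter) as well. No further data are available to explain these results.

As far as these compounds go, all four compounds lie within the scatter of one another, so it remains open whether any group at this position can move the read-out. An amine or a carboxylic acid at the end of the chain, or a longer chain carrying the carbamate, would be a sharper test.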